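This account rests on a few compounds, and the source may have more. Where it says the series, first, only, none or still open, it means among the compounds named here.

Measured so far in an assay (Cricetulus griseus) for inhibition of aldehyde dehydrogenase, mitochondrial (Homo sapiens); on this read-out lower numbers stand for stronger inhibition and higher numbers for weaker inhibition:
- compound 1, `O=C(O)COc1ccc(-c2coc3cc(OCC(=O)O)ccc3c2=O)cc1`: >> 9000 nM
- compound 2, `O=c1c(-c2ccc(O)cc2)coc2cc(OCCCCCCCCCO)ccc12`: 700 nM
- compound 3, `CCCCC(Oc1ccc2c(=O)c(-c3ccc(O)cc3)coc2c1)C(=O)OCC`: 4500 nM

The value for compound 1 is a limit of this assay, not a number. Among the numbers, compound 2 stands lowest; compound 3 sits higher, beyond the scatter, and no single-point step links the two. Within the data shown here, the only measured compound bearing carboxy groups is compound 1, which gave a limit (the limit of >> 9000 nM in this assay, at which 1 of the 3 values shown sits).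

Compound 4, `O=C(O)CCCCCCCCCOc1ccc2c(=O)c(-c3ccc(O)cc3)coc2c1`, has not been measured in this assay. It differs from compound 2 as follows: carboxy in place of hydroxy on a saturated chain carbon, nine bonds along the chain from an oxygen on an aromatic ring. A moderate weakening, beyond the scatter, is expected from compound 2 to compound 4, as a 2.9-fold higher number from compound 2 to compound 4 (0.46 log units; beyond the scatter). Compound 4 is therefore estimated at 2000 nM, within 500 nM to 8000 nM.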

Compound 4, half-maximal inhibitory concentration: 50 nM
For compound 4 the middle estimate is 40-fold (1.60 log units) above the measured one; measured number outside the range, below it.
By their numbers in this assay, from the lowest: compound 4; then compound 2; then compound 3. At a limit, above all of these: compound 1.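

On the saturated chain carbon nine bonds along the chain from an oxygen on an aromatic ring, the group carried there matters strongly in this assay: carboxy in place of hydroxy gives a 14-fold lower number from compound 2 to compound 4 (1.15 log units; beyond the scatter). Among these compounds, this is the only single-place step, and it shows that carboxy at this position is compatible with the lowest number so far. Nothing measured here gives a cause for this step.

Open, going by these compounds, is whether a shorter or longer chain keeps this gain with carboxy in the same place. Also open, on these data alone, is whether a primary amide, a methyl ester or an amine at that position behaves like carboxy or like hydroxy.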